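Trimming the Sulfonyl Substituent from Aryl to Methyl

The source may report more compounds than this note shows. Statements on the series, on what has been measured and on what is new or still open speak of the compounds shown alone.

Measured in an assay on cells for inhibition of HSP60/HSP10 (Homo sapiens), with a stated time of 60 min; a lower number here means a stronger inhibitor, a higher number a weaker inhibitor:
Compound 1 `COc1ccccc1S(=O)(=O)Nc1ccc2oc(-c3ccccc3)nc2c1`: > 100000 nM
Compound 2 `COc1ccc(Cl)cc1S(=O)(=O)Nc1ccc2oc(-c3ccccc3)nc2c1`: > 100000 nM

The value of compound 1 is a limit of the assay. The value of compound 2 is likewise a limit, so the step that the two limits leave unreadable from compound 1 to compound 2 cannot be read. Compound 2 thus stands at the limit of > 100000 nM in this assay, at which 2 of the 2 values shown sit. Compound 3 `CS(=O)(=O)Nc1ccc2oc(-c3ccccc3)nc2c1` differs from compound 2 by methyl in place of 5-chloro-2-methoxyphenyl on a sulfonyl sulfur. For the measured compounds named here, no measured step touches this change, and the one step recorded is unreadable, so neither a size nor a direction beyond the scatter can be drawn for this assay. Compound 3 is expected at 100000 nM, within 20000 nM to 300000 nM. The expected step is a number no higher from compound 2 to compound 3 (the limit leaves the size open).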

Compound 3, half-maximal inhibitory concentration: > 100000 nM
Compound 3: a limit, no number; the forecaster's own chance of this, stated with the estimate: 80%; the middle value sits exactly at the limit.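

In this assay compound 3 gives > 100000 nM, a limit of the assay. The steps from compound 1 and from compound 2 to compound 3 cannot be read. The compounds shown leave open whether any sulfonyl substituent on this shared core gives a measurable inhibition.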